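Ester to acid on the amide-linked chain: compound 4

A few compounds are considered here, and "the series" means these few. Any claim that something is new, unique, unknown or untested is made for them only; others in the source may bear on it.

Measured so far in this series:
compound 1, `CCN(CC)CCCNC(=O)c1ccc(C(CC)(CC)c2ccc(C#CC(O)(CC)CC)c(C)c2)n1CC`: 68.9 nM
compound 2, `CCn1c(C(=O)NCc2ccc(OC)cc2)ccc1C(CC)(CC)c1ccc(C#CC(O)(CC)CC)c(C)c1`: a limit, > 50 nM
compound 3, `CCn1cc(C(CC)(CC)c2ccc(C#CC(O)(CC)CC)c(C)c2)cc1C(=O)NCC(=O)OC`: 288 nM

In an assay on cells for agonist activity at vitamin D3 receptor (Homo sapiens), read by microscopy (a higher number here means that more compound is needed for the effect, a lower number that less compound is needed), compound 1 gives 68.9 nM. Compound 2 gives only a limit in this assay, > 50 nM. Compound 3 gives 288 nM, the higher of the two numbers; compound 1 lies nearest, and the gap between them is beyond the scatter. For the measured compounds named here, the single step between measured compounds, a step that the limit leaves unreadable from compound 1 to compound 2, cannot be sized because of the limit of > 50 nM in this assay, at which 1 of the 3 values shown sits.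

Compound 4, `CCn1cc(C(CC)(CC)c2ccc(C#CC(O)(CC)CC)c(C)c2)cc1C(=O)NCC(=O)O`, is not yet measured. It differs from compound 3 by hydrogen in place of methyl on an oxygen next to a carbonyl group. No measured step touches this position or this kind of change, and the one step that exists is unreadable, so nothing shown gives a direction. The expectation for compound 4 therefore rests on compound 3 alone, with a wide range: the step of a 1.7-fold higher number from compound 3 to compound 4 (0.24 log units; within the scatter) is expected to be modest, leaning to a higher number. Compound 4 is estimated at 500 nM, between 150 nM and 2000 nM.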

Compound 4, half-maximal effective concentration: 54.3 nM
For compound 4 the middle estimate is 9.2-fold (0.96 log units) above the measured one, and the stated range ends above it.
By their numbers in this assay, from the lowest: compounds 4 and 1 (each within the scatter of the next); then compound 3.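

In this assay, hydrogen in place of methyl on an oxygen next to a carbonyl group gives a 5.3-fold lower number from compound 3 to compound 4 (0.72 log units; beyond the scatter), so methoxycarbonyl to carboxy on this chain moves the number towards less compound needed. For the compounds shown here, until now no step touched this position, and the only earlier step, which involves a limit for compound 2, cannot be read: the limit of > 50 nM in this assay, at which 1 of the 4 values shown sits. Nothing measured here bears on why the step runs in this direction.

As far as these compounds go, this single pair is all that speaks for the position, so it remains open whether a primary amide, a tetrazole or a longer chain carrying the carboxy group would give a number like that of compound 4. Also open, from the compounds shown here alone, is whether the same change from methoxycarbonyl to carboxy runs the same way on the core of compound 1.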